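Trading chlorophenyl for cyanophenyl on the sulfonyl group

The source may hold more compounds than are shown below. What is called first, only, known or untested is meant among the compounds shown, and "the series" means these compounds.

Compound 1 `Cc1ccc(S(=O)(=O)n2cc(C3CNC(C(C)C)=N3)c3ccccc32)cc1`: 70000 nM
Compound 2 `CC1=NC(c2cn(S(=O)(=O)c3cccc(Cl)c3)c3ccccc23)CN1`: > 30000 nM (a limit)
Compound 3 `CC1=NC(c2cn(S(=O)(=O)c3cccc(Cl)c3)c3ccc(C)cc23)CN1`: 30000 nM

In an assay on isolated protein for inhibition of kallikrein-7 (Homo sapiens), read by fluorescence, with stated times of 10 min and 30 min (a higher number here means a weaker inhibitor, a lower number a stronger inhibitor), compound 1 gives 70000 nM. Compound 2 reaches only a limit, > 30000 nM, in this assay. Compound 3 gives 30000 nM, the lowest of the two numbers; compound 1 sits a step higher that is beyond the scatter. For the measured compounds named here, the one measured step, a number no higher from compound 2 to compound 3 (the limit leaves the size open), has no readable size because of the limit of > 30000 nM in this assay, at which 1 of the 3 values shown sits.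

Compound 4 `CC1=NC(c2cn(S(=O)(=O)c3ccccc3C#N)c3ccc(C)cc23)CN1` carries the change (2-cyanophenyl in place of 3-chlorophenyl on a sulfonyl sulfur). Going by the values given here, no measured step touches this position, and compound 1 differs from compound 3 in more than one place, so nothing sets the size. The expectation is a step within the scatter, no change at the digits printed from compound 3 to compound 4 (within the scatter), giving an estimate for compound 4 of 30000 nM, between 8000 nM and 100000 nM.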

Compound 4, half-maximal inhibitory concentration: 6700 nM
The estimate for compound 4 lay 4.5-fold (0.65 log units) above the measured number; the measured number lies below the stated range.
By their numbers in this assay, from the lowest: compound 4; then compound 3; then compound 1.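

In this assay, for the compounds shown here, the group on the sulfonyl sulfur turns out to matter: replacing 3-chlorophenyl with 2-cyanophenyl gives a 4.5-fold lower number from compound 3 to compound 4 (0.65 log units; beyond the scatter), the first readable step at this position. Both the substituent and its printed ring number change together, so this single step cannot be assigned to either one alone. Nothing shown accounts for the lower number.

Going by these compounds, whether 3-cyanophenyl or 2-chlorophenyl on the sulfonyl sulfur would give a similar number remains open. So does the outcome with an aminophenyl or a carboxyphenyl group there.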